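The source may report more compounds than this note shows. Statements on the series, on what has been measured and on what is new or still open speak of the compounds shown alone.

Compound 1, `CCOC(=O)CN(c1ccccc1)C1c2cc(C#N)ccc2OC(C)(C)C1O`, in a functional assay (aorta) with Rattus norvegicus as the target (a lower number here means a stronger inhibitor, a higher number a weaker inhibitor), gives only a limit of the assay, > 30000 nM.
Compound 2, `CCOC(=O)CN(c1ccccc1)[C@@H]1c2cc(C#N)ccc2OC(C)(C)[C@H]1O`, in this assay gives only a limit, > 30000 nM.
Compound 3, `CCOC(=O)CN(c1ccc(F)cc1)[C@H]1c2cc(C#N)ccc2OC(C)(C)[C@@H]1O`, in this assay gives only a limit, > 30000 nM.

Compound 3 therefore stands where every measured compound stands: at the limit, with no number to rank it against the others. Going by the values given here, the one measured step, a step that the two limits leave unreadable from compound 1 to compound 2, cannot be read because of the limit of > 30000 nM in this assay, at which 3 of the 3 values shown sit; the pair differs only in the fact that one of compounds 1 and 2 is drawn with a defined configuration and the other without, at the place where they differ. Compound 4, `CCOC(=O)CN(c1nc2ccccc2o1)[C@H]1c2cc(C#N)ccc2OC(C)(C)[C@@H]1O`, differs from compound 3 by 1,3-benzoxazol-2-yl in place of 4-fluorophenyl on an amine nitrogen. No measured step touches this group, so nothing shown supports a gain or a loss; in this assay compound 4 is expected again to sit near the limit, an estimated 30000 nM, spanning 5000 nM to 100000 nM, a step of a number no higher from compound 3 to compound 4 (the limit leaves the size open).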

Compound 4, half-maximal inhibitory concentration: > 30000 nM
Compound 4 gave a limit, no number; the forecaster's own chance of this, stated with the estimate: 70%; the middle value sits exactly at the limit.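

Going by these compounds alone, compound 3 and compound 4 both give only a limit in this assay, and no step between them can be read. Going by these compounds, whether 1,3-benzoxazol-2-yl and 4-fluorophenyl on the amine nitrogen differ in strength remains open.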